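Does the mirror image of compound 2 behave alike?

The source may hold more compounds than are shown below. What is called first, only, known or untested is meant among the compounds shown, and "the series" means these compounds.

- compound 1 `O[C@H](c1ccccn1)[C@]1(c2cccc(OC(F)(F)F)c2)C[C@@H](O)C1` gives 117 mL/min/kg in the first measurement
- compound 2 `C[C@]1(c2ccc(OC(F)(F)F)cc2)C[C@@](O)(c2ccccn2)CO1` gives 117 mL/min/kg in the second
- compound 3 `OC(c1ccccn1)C1(c2ccc(C(F)(F)F)cc2)CNC1` gives 33.3 mL/min/kg in the third

In an ADME assay on liver for metabolic stability, with Liver microsome (Homo sapiens) as the target, read by LC-MS, using microsomes, with a stated time of 5 h (on this read-out higher numbers stand for fast clearance and lower numbers for slow clearance), compound 2 stands level with compound 1, while compound 3 gives a lower number, a gap beyond the usual scatter. The next molecule is compound 4 `C[C@@]1(c2ccc(OC(F)(F)F)cc2)C[C@](O)(c2ccccn2)CO1` and the change is the two compounds have the same atoms and bonds and differ only in configuration as drawn: 2 of 2 stereo elements differ (all stereocentres are inverted: mirror images); a stereocentre at a saturated ring carbon is drawn R in compound 2 and S in compound 4; a stereocentre at a saturated ring carbon is drawn R in compound 2 and S in compound 4 so that all stereocentres are inverted and the two are mirror images. Among the measured compounds shown here, no pair of mirror images has been measured here, so the data give no size for such a step. The expectation is a small fall, a 1.2-fold lower number from compound 2 to compound 4 (0.07 log units; within the scatter) as the estimated step, with no change beyond the scatter. Compound 4 is estimated at 100 mL/min/kg with an expected range from 50 mL/min/kg to 130 mL/min/kg in this estimate.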

Compound 4, clearance: 217 mL/min/kg
Beside the measured number, compound 4's estimate is 2.2-fold (0.34 log units) below it, outside the stated range (above it).
By their numbers in this assay, from the lowest: compound 3; then compounds 1, 2 and 4 (each within the scatter of the next).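

Among the compounds shown here, this is the first pair of mirror images in the set, and in this assay the step is a 1.9-fold higher number from compound 2 to compound 4 (0.27 log units; within the scatter), so inverting both stereocentres gives no change beyond the scatter for this pair. For the compounds shown here, one pair sets no rule for other compounds. Configuration is the only thing that could have separated these two readings: the fact that compounds 2 and 4 differ only in the configuration as drawn

As far as these compounds go, what inverting just one of the two stereocentres would do remains open. From the compounds shown here alone, it is also open whether mirror images would stay this close with a carboxylic acid or a nitrile in place of the trifluoromethoxy group.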